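A few compounds are considered here, and "the series" means these few. Any claim that something is new, unique, unknown or untested is made for them only; others in the source may bear on it.

Measured compounds:
compound 1, `Cc1cc(NC(=O)Cn2nnc(-c3ccc(F)cc3)n2)n(C2CCCCC2)n1`, 92%
compound 2, `Cc1cc(NC(=O)Cn2nnc(-c3ccc(F)c(F)c3)n2)n(C2CCCCC2)n1`, 93%

Of the compounds shown here, two have been measured in an assay on HEK293 cells for activation of Kir3.1/Kir3.2 (Homo sapiens), read by thallium flux; on this read-out lower numbers stand for smaller maximal responses and higher numbers for larger maximal responses. Compound 1 gives 92%, and compound 2 gives 93%. The only difference between them is a fluoro in place of hydrogen on an aromatic carbon, and the step, a number 1 percentage points higher from compound 1 to compound 2 (within the scatter), lies within the scatter, so the two compounds cannot be told apart on this read-out: both reach nearly the full response of the reference.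

Compound 3, `Cc1cccc(-c2nnn(CC(=O)Nc3cc(C)nn3C3CCCCC3)n2)c1`, has not yet been measured. It differs from compound 2 in one place: 3-methylphenyl in place of 3,4-difluorophenyl on an aromatic carbon. For the measured compounds named here, the one measured step, from compound 1 to compound 2, concerns the same phenyl ring and swaps a hydrogen for a fluoro, and it changed nothing beyond the scatter. Going by the values given here, that step is the only guide here, and it points to the maximal response in this assay being insensitive to what sits on that phenyl ring, at least for the small change seen so far. A change from 3,4-difluorophenyl to 3-methylphenyl is somewhat larger than that single step, so more uncertainty is warranted, but no direction is indicated. Compound 3 is therefore expected to show no step beyond the scatter, a number 3 percentage points lower from compound 2 to compound 3 (within the scatter), and its maximal response is estimated at 90%, with a range from 78% to 100%.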

Compound 3, largest response reached (Emax), in percent of the reference or control that the assay uses: 93%
Beside the measured number, compound 3's estimate is 3 percentage points below it; low and high end bracket the measured number.
By their numbers in this assay, from the lowest: compounds 1, 2 and 3 (each within the scatter of the next).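

In this assay, the swap of 3,4-difluorophenyl for 3-methylphenyl gives no change at the digits printed from compound 2 to compound 3 (within the scatter), and the swap of 4-fluorophenyl for 3-methylphenyl gives a number 1 percentage points higher from compound 1 to compound 3 (within the scatter). The earlier pair differed by a single fluoro on the ring, whereas these steps remove all fluorine and bring in a methyl group, so the maximal response holds across a wider change at this position, on the aromatic carbon between two ring nitrogen atoms. Nothing available explains why this response stays the same across these groups.

All three compounds carry a six-membered aromatic ring of carbon only at this position, with no hydrogen-bond donors or acceptors and no net charge in the group. The compounds shown therefore leave open whether the maximal response would hold with an amine or a carboxylic acid on that ring, or with a longer chain such as butyl in place of the methyl group.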